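The compounds below may be only part of what the source reports. "The series", "measured", "known", "first", "only" and "open" are said of these compounds alone.

Measured so far:
- compound 1, `COc1ccc(-c2cc(-c3ccc(NS(C)(=O)=O)cc3)cnc2N)cn1`, 2.2
- compound 2, `COc1ccc(-c2cc(-c3ccc4nccn4c3)cnc2N)cn1`, 2.4

Both compounds were run in a physicochemical assay for lipophilicity, at pH 7.4; a lower number here means a more polar compound, a higher number a more lipophilic compound. In this assay compound 1 gives 2.2, and compound 2 gives 2.4. Compound 1 has the lowest of the two numbers, but the gap to compound 2 lies within the scatter, so the two cannot be told apart on these data. Going by the values given here, compound 1 and compound 2 differ in a whole ring system, and no single step between them is counted here.

The next compound, compound 3, `COc1ccc(-c2cc(-c3ccc(C(N)=O)cc3)cnc2N)cn1`, is not yet measured. It keeps the shared core of compound 1 and changes one group: carbamoyl in place of methanesulfonamido on an aromatic carbon, in words carbamoyl in place of methanesulfonamido on an aromatic carbon. Among the compounds with values here, no measured pair shows this exchange, so there is no step to lean on. The group that leaves and the group that enters each carry one hydrogen-bond donor; the group that enters is the smaller one. For the exchange from compound 1 to compound 3 in this assay no shift beyond the scatter is expected, perhaps a small drop, and the expected step is a number 0.20 log units lower from compound 1 to compound 3 (within the scatter). Compound 3 is therefore estimated at 2, with a likely range from 1.5 to 2.5.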

Compound 3, distribution coefficient: 1.7
Beside the measured number, compound 3's estimate is 0.30 log units above it; the measured number falls inside the stated range.
By their numbers in this assay, from the lowest: compound 3; then compounds 1 and 2 (each within the scatter of the next).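

In this assay, going by these compounds alone, putting carbamoyl in place of methanesulfonamido on this aromatic carbon gives the first step in the set that clears the scatter: a number 0.50 log units lower from compound 1 to compound 3 (beyond the scatter). The numbers for compound 1 and compound 2 could not be told apart, so they gave no sign that a change at this position moves the read-out; here an exchange of one group, with the shared core left as it is, does move it. Nothing measured here bears on why the number moves, and the step alone cannot separate the differences between the two groups, such as the smaller size of carbamoyl or the loss of sulfur.

The compounds shown leave open how other groups on this aromatic carbon would read in this assay, for instance an amine, a carboxylic acid or a nitrile, which would show how far the number can travel at this position. They also leave open whether the same exchange would give a step of similar size on a different core, since this is a single pair.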